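The compounds below may be only part of what the source reports. "The series", "measured", "known", "first", "only" and "open" are said of these compounds alone.

Measured so far:
compound 1, `C=C1C(=O)N(c2ccccc2)N(c2ccccc2)C1c1ccccc1`: 3820 nM
compound 2, `C=C1C(=O)N(c2ccccc2)N(C)C1C`: 412000 nM

The read-out is a functional assay on NALM-6 cells (Homo sapiens) for inhibition, read by MTT assay, with a stated time of 48 h; a higher number here means a weaker inhibitor, a lower number a stronger inhibitor. Compound 2 holds the higher of the two numbers, and its gap to compound 1 lies beyond the scatter, so of the two, compound 2 is the weaker inhibitor. Compound 3, `C=C1C(=O)N(c2ccccc2)N(c2ccccc2)C1C`, has not been measured. It differs from compound 2 in one place: phenyl in place of methyl on an amine nitrogen in a ring. Among the measured compounds shown here, no step between measured compounds is known, so the size of this change cannot be read off directly. It is expected to lower the number in this assay by a clear step, because compound 1 gives 3820 nM while compound 2 gives 412000 nM, and compound 3 is expected to fall between them. Compound 3 is estimated at 40000 nM, within 10000 nM to 150000 nM. The expected step is a 10-fold lower number from compound 2 to compound 3 (1.01 log units; beyond the scatter).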

Compound 3, half-maximal inhibitory concentration: 6980 nM
For compound 3 the middle estimate is 5.7-fold (0.76 log units) above the measured one; the whole stated range lies above it.
By their numbers in this assay, from the lowest: compounds 1 and 3 (each within the scatter of the next); then compound 2.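

In this assay, phenyl in place of methyl on the amine nitrogen in the ring gives a 59-fold lower number from compound 2 to compound 3 (1.77 log units; beyond the scatter), so this single change is a large one, and the ring nitrogen is a position where the series responds strongly. On the saturated ring carbon, methyl in place of phenyl gives a 1.8-fold higher number from compound 1 to compound 3 (0.26 log units; within the scatter), within the scatter, so with phenyl on the ring nitrogen these two groups cannot be told apart at that carbon. No data on hand explain either result.

From the compounds shown here alone, it remains open whether phenyl on the ring nitrogen can be replaced by benzyl, cyclohexyl or a longer chain with a similar result. Also open, going by these compounds, is how the saturated ring carbon responds to an amine or a carboxylic acid.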